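This account rests on a few compounds, and the source may have more. Where it says the series, first, only, none or still open, it means among the compounds named here.

Measured so far:
- compound 1, `O=C(NCc1ccc(F)cc1)c1nc(Br)c2cccnc2c1NCc1ccc(F)cc1`. In a functional assay on HCT-116 cells (Homo sapiens) for cytotoxicity, read by MTT assay, with a stated time of 72 h (on this read-out higher numbers stand for weaker inhibition and lower numbers for stronger inhibition), compound 1 gives > 20000 nM, which is a limit of the assay rather than a number.
- compound 2, `N[C@H]1CC[C@H](Nc2c(C(=O)NCc3ccc(F)cc3)nc(Br)c3cccnc23)CC1`. Compound 2 gives 7000 nM.
- compound 3, `NCCNc1c(C(=O)NCc2ccc(F)cc2)nc(Br)c2cccnc12`. Compound 3 gives > 20000 nM, again a limit of the assay.

For the measured compounds named here, compound 2 therefore stands as the only compound of the three with an actual number; the other two sit at the limit of > 20000 nM in this assay, at which 2 of the 3 values shown sit. Both measured steps concern the substituent on the ring nitrogen: an at least 2.8-fold lower number from compound 1 to compound 2 (0.45 log units; beyond the scatter), and an at least 2.8-fold higher number from compound 2 to compound 3 (0.45 log units; beyond the scatter). The step that the two limits leave unreadable from compound 1 to compound 3 cannot be read between two limits.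

Compound 4, `N[C@H]1CC[C@H](Nc2c(C(=O)NCc3ccc(Cl)cc3)nc(Br)c3cccnc23)CC1`, differs from compound 2 elsewhere: chloro in place of fluoro on an aromatic carbon, sitting on the benzyl amide rather than on the ring nitrogen. Going by the values given here, none of the measured steps touches this position, so no measured step bears on it, and the expectation is a step within the scatter, in no particular direction.

Compound 4 is thus expected to give 5500 nM, between 2000 nM and 15000 nM, that is an estimated 1.3-fold lower number from compound 2 to compound 4 (0.10 log units; within the scatter).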

Compound 4, half-maximal inhibitory concentration: 4000 nM
Compound 4: middle estimate off by 1.4-fold (0.14 log units), on the high side; the measured number falls inside the stated range.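

Chloro in place of fluoro on an aromatic carbon, para to a large group, is the first change at the benzyl amide, and in this assay it gives a 1.8-fold lower number from compound 2 to compound 4 (0.24 log units; within the scatter), a step within the scatter. With 4-aminocyclohexyl held on the ring nitrogen, 4-fluorobenzyl and 4-chlorobenzyl on the amide therefore read alike, whereas the earlier readable steps all concerned the substituent on the ring nitrogen. Nothing available bears on a cause for this step.

From the compounds shown here alone, whether an amine, a carboxylic acid or a methoxy group at this same place on the benzyl ring would move the number beyond the scatter remains open. Going by these compounds, compound 3 gives > 20000 nM, a limit of the assay, so the effect of this exchange with 2-aminoethyl on the ring nitrogen also stays open.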